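This account rests on a few compounds, and the source may have more. Where it says the series, first, only, none or still open, it means among the compounds named here.

Measured compounds:
compound 1 `CC(C)(C)C(=O)OCC(CCc1ccc(C(C)(C)C)cc1)NC(=S)NCc1ccc(NS(C)(=O)=O)c(F)c1` — 190 nM
compound 2 `CC(C)(C)C(=O)OCC(NC(=S)NCc1ccc(NS(C)(=O)=O)cc1)c1ccc(C(C)(C)C)cc1` — 197 nM

In an assay on CHO cells for displacement of a labelled ligand from transient receptor potential cation channel subfamily V member 1 (Rattus norvegicus) (on this read-out lower numbers stand for stronger inhibition and higher numbers for weaker inhibition), compound 1 gives 190 nM and compound 2 gives 197 nM. Compound 2 stands at the higher of the two numbers, yet compound 1 lies so close that the gap between the two falls within the usual scatter, so no order can be read between them. Among the compounds with values here, no step between measured compounds that differ in a single place is available, and compound 1 and compound 2 differ in more than one place.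

The unmeasured compound 3 `CC(C)(C)C(=O)OCC(NC(=S)NCc1ccc(NS(C)(=O)=O)c(F)c1)c1ccc(C(C)(C)C)cc1` is reached from compound 2 by one change: fluoro in place of hydrogen on an aromatic carbon. Within the data shown here, with no single-place step to lean on, the expectation for compound 3 is a step from compound 2 of a 1.3-fold lower number from compound 2 to compound 3 (0.12 log units; within the scatter) in this assay, a shift not clearly beyond the scatter. Compound 3 is therefore estimated at 150 nM, within 60 nM to 400 nM.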

Compound 3, inhibition constant: 244 nM
The estimate for compound 3 lay 1.6-fold (0.21 log units) below the measured number, within the range that was stated.
By their numbers in this assay, from the lowest: compounds 1, 2 and 3 (each within the scatter of the next).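

In this assay, fluoro in place of hydrogen on an aromatic carbon, ortho to a methanesulfonamido group, gives a 1.2-fold higher number from compound 2 to compound 3 (0.09 log units; within the scatter) and so produces no readable change at this position. With that fluoro present on both compounds, 4-(tert-butyl)phenyl in place of 2-(4-(tert-butyl)phenyl)ethyl gives a 1.3-fold higher number from compound 1 to compound 3 (0.11 log units; within the scatter), so this difference in the chain cannot be read as a change either. Nothing available explains either result.

The compounds shown leave open whether chloro or methoxy at the same aromatic carbon would move the number beyond the scatter. They also leave open whether a longer chain between the saturated carbon and the 4-(tert-butyl)phenyl group would do so.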